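The compounds below may be only part of what the source reports. "The series", "measured", "known", "first", "only" and "open" are said of these compounds alone.

Measured compounds:
compound 1, `CCCCCCCc1ccc(NC(=O)N[C@H](C)c2ccccc2)cc1`: 100%
compound 2, `CCCCCCCc1ccc(NC(=O)N[C@@H](C)c2ccccc2)cc1`: 99%
compound 3, `CC(=O)c1ccc(NC(=O)N[C@H](C)c2ccccc2)cc1`: 84%

In an ADME assay on the whole organism with Oryza sativa as the target, tested at 10 uM (a higher number here means a weaker effect of the compound at the concentration tested, a lower number a stronger effect), compound 2 stands second highest of the three numbers. Its nearest neighbour is compound 1, which gives 100% in this assay, and the step of a number 1 percentage points lower from compound 1 to compound 2 (within the scatter) is within the scatter, which fits (the fact that compounds 1 and 2 differ only in the configuration as drawn). The furthest is compound 3, whose value in this assay is 84%; the step of a number 16 percentage points lower from compound 1 to compound 3 (beyond the scatter) is modest but beyond the scatter.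

Compound 4, `C[C@H](NC(=O)Nc1ccc(I)cc1)c1ccccc1`, has not yet been measured. It differs from compound 2 by iodo in place of heptyl on an aromatic carbon. For the measured compounds named here, the only measured step that bears on this change is the one from compound 1 to compound 3, where another group took the place of heptyl on the aromatic carbon and gave a number 16 percentage points lower from compound 1 to compound 3 (beyond the scatter). The step from compound 1 to compound 2 is not informative here, since it involved no change of the group on that carbon.

For compound 4 the step of a number 7 percentage points lower from compound 2 to compound 4 (within the scatter) is therefore expected to be small, in the lowering direction or none beyond the scatter. The estimate for compound 4 in this assay is 92%, with a range from 78% to 100%.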

Compound 4, a percentage reported as activity, at one concentration (the size of the read-out at that concentration, not a potency): 95%
Compound 4: middle estimate off by 3 percentage points, on the low side, within the range that was stated.
By their numbers in this assay, from the lowest: compound 3; then compounds 4, 2 and 1 (each within the scatter of the next).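

In this assay, the result gives a number 4 percentage points lower from compound 2 to compound 4 (within the scatter), so at this aromatic carbon a heptyl chain of seven carbons can give way to a single iodine without a change beyond the scatter. Removing heptyl therefore does not by itself move the number beyond the scatter, whereas the one earlier replacement at this carbon, by acetyl, gave a number 16 percentage points lower from compound 1 to compound 3 (beyond the scatter). Nothing in the available evidence bears on why iodo and heptyl read alike here.

The compounds shown leave open whether the acetyl step would hold in the configuration of compound 2, and whether iodo would read the same in the configuration of compound 1. They also leave open what an amine, a carboxylic acid or a shorter alkyl chain would give on this carbon.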